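This account rests on a few compounds, and the source may have more. Where it says the series, first, only, none or still open, it means among the compounds named here.

Measured so far:
compound 1, `Cc1cccc(NC(=O)N[C@H](C)c2ccccc2)c1`: 100%
compound 2, `CCc1cccc(NC(=O)N[C@H](C)c2ccccc2)c1`: 97%
compound 3, `CCc1cccc(NC(=O)N[C@@H](C)c2ccccc2)c1`: 100%

In an ADME assay on the whole organism with Oryza sativa as the target, tested at 0.1 uM (a lower number here means a stronger effect, a higher number a weaker effect of the compound at the concentration tested), compound 3 gives 100% and so stands level with compound 1, whose value is 100%; compound 2 lies within the scatter of both, since the step of a number 3 percentage points higher from compound 2 to compound 3 (within the scatter) is small, and because of the fact that compounds 2 and 3 differ only in the configuration as drawn this pair shows that turning the drawn configuration around leaves the read-out essentially unchanged.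

Compound 4, `CC(C)c1cccc(NC(=O)N[C@@H](C)c2ccccc2)c1`, has not yet been measured. It differs from compound 3 in one place: methyl in place of hydrogen on a saturated chain carbon bound to an aromatic carbon and a saturated chain carbon. The closest measured comparison is the step of a number 3 percentage points lower from compound 1 to compound 2 (within the scatter), where likewise a methyl entered for a hydrogen, and that step stayed within the scatter. The same holds for the step of a number 3 percentage points higher from compound 2 to compound 3 (within the scatter). With both measured steps this small, the methyl entering compound 4 is expected to leave the read-out where compound 3 stands, with no step beyond the scatter.

For compound 4 the expected value in this assay is therefore 98%, within a range from 86% to 100%, which corresponds to an expected step of a number 2 percentage points lower from compound 3 to compound 4 (within the scatter).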

Compound 4, a percentage reported as activity, at one concentration (the size of the read-out at that concentration, not a potency): 95%
The estimate for compound 4 lay 3 percentage points above the measured number, and the stated range covers the measured number.
By their numbers in this assay, from the lowest: compounds 4, 2, 1 and 3 (each within the scatter of the next).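

In this assay, replacing ethyl with isopropyl gives a number 5 percentage points lower from compound 3 to compound 4 (within the scatter), so this position also tolerates a branch: a methyl in place of hydrogen on a saturated chain carbon bound to an aromatic carbon and a saturated chain carbon does not move the read-out beyond the scatter. The earlier compounds shown here showed this kind of change only as methyl to ethyl, so the result extends the series by one more carbon and adds the first branched group. The change now has a second reading on another core, and the two readings agree within their scatter: the same change on two cores in this assay, a number 3 percentage points lower (within the scatter) from compound 1 to compound 2 and a number 5 percentage points lower (within the scatter) from compound 3 to compound 4, 2 percentage points apart, within the scatter of two such steps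

Methyl, ethyl and isopropyl are all small saturated carbon groups, so it remains open whether a bulkier tert-butyl, a longer chain, an amine or a carboxylic acid at this place would give a step beyond the scatter. Also open is whether isopropyl would read the same with the opposite drawn configuration at the stereocentre, and whether any of these compounds would separate at a concentration other than the one tested here.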